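This account rests on a few compounds, and the source may have more. Where it says the series, first, only, none or still open, it means among the compounds named here.

For the measured compounds named here, compound 2, `N#CC1=C(N)N(c2ccc(S(N)(=O)=O)cc2)C2=C(CCCC2)C1c1c(O)ccc2ccccc12`, is the one member of this small series that gives a number rather than a limit in a functional assay on Ehrlich cells (Mus musculus) for cytotoxicity, read by trypan blue exclusion, with a stated time of 2 h; a lower number here means a stronger inhibitor, a higher number a weaker inhibitor: compound 2 gives 100 ug/mL. Compound 1, `N#CC1=C(N)N(c2ccc(S(N)(=O)=O)cc2)C2=C(CCCC2)C1c1ccccc1`, differs from it only in carrying phenyl where compound 2 carries 2-hydroxynaphthalen-1-yl on the saturated ring carbon. In this assay compound 1 reaches only the limit of > 100 ug/mL. Going by the values given here, the single measured step, a number no higher from compound 1 to compound 2 (the limit leaves the size open), therefore has no readable size, since one of its two ends is the limit described by the limit of > 100 ug/mL in this assay, at which 1 of the 2 values shown sits.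

Compound 3, `Cc1ccc(C2C(C#N)=C(N)N(c3ccc(S(N)(=O)=O)cc3)C3=C2CCCC3)o1`, is not yet measured. Its change from compound 2 is 5-methylfuran-2-yl in place of 2-hydroxynaphthalen-1-yl on a saturated ring carbon. Among the compounds with values here, no measured step covers an exchange of this kind; the only step available, that from compound 1 to compound 2, is itself unreadable in size, so nothing points to a movement beyond the usual scatter in either direction. Compound 3 is expected to give 100 ug/mL, with a range from 50 ug/mL to 200 ug/mL. The expected step is no change at the digits printed from compound 2 to compound 3 (within the scatter), not beyond the scatter, and a reading at the limit remains plausible.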

Compound 3, half-maximal inhibitory concentration: > 100 ug/mL
Compound 3: only a limit was reported; the forecaster's own chance of this, stated with the estimate: 50%; the middle value sits exactly at the limit.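

In this assay compound 3 gives > 100 ug/mL, which is a limit of the assay and not a number. On this saturated ring carbon, 5-methylfuran-2-yl therefore reads the same way as the phenyl of compound 1, and compound 2, with its 2-hydroxynaphthalen-1-yl, remains the only one of the three to give a number. The exchange of 2-hydroxynaphthalen-1-yl for 5-methylfuran-2-yl gives a number no lower from compound 2 to compound 3 (the limit leaves the size open). Neither new step can be read in size because at least one of its two ends is a limit: the limit of > 100 ug/mL in this assay, at which 2 of the 3 values shown sit.

The compounds shown do not separate the hydroxyl group from the second aromatic ring of 2-hydroxynaphthalen-1-yl, and a 2-hydroxyphenyl or a naphthalen-1-yl group on this carbon would be needed to tell them apart. They also leave open how an amine, a carboxylic acid or a longer alkyl chain at this place would read in this assay, and whether any such group would be a stronger inhibitor than compound 2.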